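A Benzyl Carbamate Variation on a Shared Core

The compounds below may be only part of what the source reports. "The series", "measured", "known", "first", "only" and "open" are said of these compounds alone.

The study concerns two measured compounds on a shared core and one that remains to be tested. Compound 1 `CCCCCCOC(=O)c1cccc(-c2ccc(OCC)cc2)c1` carries a hexyl ester and an ethoxy group; in an assay on COS-7 cells for inhibition of patatin-like phospholipase domain-containing protein 2 (Mus musculus) (on this read-out lower numbers stand for stronger inhibition and higher numbers for weaker inhibition), compound 1 reaches only > 200000 nM, which is a limit of the assay and not a number. The limit in question is the limit of > 200000 nM in this assay, at which 1 of the 2 values shown sits. For the measured compounds named here, compound 2 `COC(=O)Nc1cccc(-c2ccc(N(C)C)cc2)c1` holds a methyl carbamate and a dimethylamino group, and in this assay compound 2 gives 5000 nM, the only measured number in the set. Compound 3 `CN(C)c1ccc(-c2cccc(NC(=O)OCc3ccccc3)c2)cc1` differs from compound 2 by a single change: phenyl in place of hydrogen on a saturated chain carbon bound to an oxygen next to a carbonyl group. Going by the values given here, no measured step between two numbered compounds exists for comparison. The expected step of a 1.7-fold lower number from compound 2 to compound 3 (0.22 log units; within the scatter) is modest, leaning toward stronger inhibition but close to the scatter of the assay. For compound 3 in this assay the estimate is 3000 nM, with a range from 800 nM to 12000 nM.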

Compound 3, half-maximal inhibitory concentration: > 200000 nM
Compound 3 was reported as a limit; the forecaster's own chance of this, stated with the estimate: 10%; at least 66-fold (1.82 log units) between middle value and limit.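

In this assay, phenyl in place of hydrogen on a saturated chain carbon bound to an oxygen next to a carbonyl group gives an at least 40-fold higher number from compound 2 to compound 3 (1.60 log units; beyond the scatter). For the compounds shown here, this is the first step that can be read on the shared core, and it shows that this one change, with the dimethylamino group kept, is enough to turn a measured number into a limit. The value of compound 3 is a limit of the assay and not a number, so the full size of the step stays unknown, and such limits now make up most of the set: the limit of > 200000 nM in this assay, at which 2 of the 3 values shown sit.

The compounds shown leave open whether a longer chain in place of the methyl would still give a measured number in this assay, or whether the result is specific to the phenyl ring. They also leave open how an amine or a carboxylic acid on that chain would read.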